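Lengthening the Alkyl Group on a Charged Oxime Core

A few compounds are considered here, and "the series" means these few. Any claim that something is new, unique, unknown or untested is made for them only; others in the source may bear on it.

Three charged oximes have been measured in a physicochemical assay for lipophilicity; a lower number here means a more polar compound, a higher number a more lipophilic compound. Compound 1 (`CC[n+]1ccn(CCN(C)C)c1/C=N/O`) gives -2.71, compound 2 (`CC[n+]1ccn(CCCC(C)(C)[N+](=O)[O-])c1/C=N/O`) gives -1.8, and compound 3 (`C[n+]1ccn(CCCS(C)(=O)=O)c1/C=N/O`) gives -2.7. In this assay compound 3 thus sits within the scatter of compound 1, while compound 2 lies beyond the scatter above both of them. Compound 4 (`CC[n+]1ccn(CCCS(C)(=O)=O)c1/C=N/O`) has not yet been measured; it differs from compound 3 by methyl in place of hydrogen on a saturated chain carbon bound to an aromatic nitrogen. Within the data shown here, no measured pair in this set shows the same change, so the expected step cannot be read from a comparison within it. A small rise in lipophilicity, roughly at the edge of the scatter, is expected, a number 0.35 log units higher from compound 3 to compound 4 (beyond the scatter). Compound 4 is accordingly estimated at -2.35, with a range from -2.75 to -1.95.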

Compound 4, distribution coefficient: -2.6
Beside the measured number, compound 4's estimate is 0.25 log units above it, within the range that was stated.
By their numbers in this assay, from the lowest: compounds 1, 3 and 4 (each within the scatter of the next); then compound 2.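

In this assay, among these compounds, the first matched pair for this change, methyl in place of hydrogen on a saturated chain carbon bound to an aromatic nitrogen, gives a number 0.10 log units higher from compound 3 to compound 4 (within the scatter) and so leaves the number unchanged within the scatter. Among the other listed changes, methylsulfonyl in place of 1-methyl-1-nitroethyl gives a number 0.80 log units lower from compound 2 to compound 4 (beyond the scatter) while (methylsulfonyl)methyl in place of dimethylamino gives a number 0.11 log units higher from compound 1 to compound 4 (within the scatter) and only the former lies beyond the scatter. No available evidence explains these steps.

On these data alone, whether a propyl group or a longer chain at this place would move the number beyond the scatter remains open. So does whether methyl to ethyl behaves alike when the other chains carry dimethylamino or 1-methyl-1-nitroethyl.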